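Triazole-linked sugar variants on the shared core

This account rests on a few compounds, and the source may have more. Where it says the series, first, only, none or still open, it means among the compounds named here.

Compound 3 `O=C1c2c[n+]([O-])c3ccccc3c2C(=O)c2c1c1ccccc1n2Cc1cn(CC(O)CO)nn1` carries a 2,3-dihydroxypropyl group on the triazole nitrogen. In a functional assay on MCF7 cells (Homo sapiens) for cytotoxicity, read by MTT assay, with a stated time of 72 h (on this read-out lower numbers stand for stronger inhibition and higher numbers for weaker inhibition), compound 3 gives 1110 nM, the highest number among the three measured compounds. Compound 1 `O=C1c2c[n+]([O-])c3ccccc3c2C(=O)c2c1c1ccccc1n2Cc1cn([C@H]2C[C@H](O)[C@@H](CO)O2)nn1` gives 530 nM in this assay, and compound 2 `CC1(C)OCC(Cn2cc(Cn3c4c(c5ccccc53)C(=O)c3c[n+]([O-])c5ccccc5c3C4=O)nn2)O1` gives 290 nM. Both steps toward compound 3 raise the number: a 2.1-fold higher number from compound 1 to compound 3 (0.32 log units; beyond the scatter) and a 3.8-fold higher number from compound 2 to compound 3 (0.58 log units; beyond the scatter).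

Compound 4 `O=C1c2c[n+]([O-])c3ccccc3c2C(=O)c2c1c1ccccc1n2Cc1cn([C@H]2O[C@H](CO)[C@@H](O)[C@H]2O)nn1` differs from compound 3 in one place: 3,4-dihydroxy-5-(hydroxymethyl)oxolan-2-yl in place of 2,3-dihydroxypropyl on an aromatic nitrogen. Among the measured compounds shown here, the closest precedent is the reverse of a 2.1-fold higher number from compound 1 to compound 3 (0.32 log units; beyond the scatter), in which a 4-hydroxy-5-(hydroxymethyl)oxolan-2-yl ring stood where compound 3 has the open chain; the ring entering in compound 4 is related but not the same, so the precedent is only approximate. The step of a 3.8-fold higher number from compound 2 to compound 3 (0.58 log units; beyond the scatter) points in the same direction, with a ring attached through a chain rather than directly. On this basis compound 4 is expected to show a modest lowering of the number, a 2.0-fold lower number from compound 3 to compound 4 (0.30 log units; within the scatter), bringing it close to compound 1. The estimate for compound 4 in this assay is 550 nM, expected within 250 nM to 1200 nM.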

Compound 4, half-maximal inhibitory concentration: 1490 nM
Compound 4: the middle estimate sits 2.7-fold (0.43 log units) below what was measured, outside the stated range (above it).
By their numbers in this assay, from the lowest: compounds 2 and 1 (each within the scatter of the next); then compounds 3 and 4 (each within the scatter of the next).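

In this assay, a ring attached directly to the aromatic nitrogen does not by itself lower the number: 3,4-dihydroxy-5-(hydroxymethyl)oxolan-2-yl in place of 2,3-dihydroxypropyl gives only a step within the scatter (a 1.3-fold higher number from compound 3 to compound 4 (0.13 log units; within the scatter)). The two directly attached rings are also not interchangeable at this position, since the 3,4-dihydroxy ring in place of the 4-hydroxy ring gives a step beyond the scatter (a 2.8-fold higher number from compound 1 to compound 4 (0.45 log units; beyond the scatter)). Replacing (2,2-dimethyl-1,3-dioxolan-4-yl)methyl with the same 3,4-dihydroxy ring gives a larger step (a 5.1-fold higher number from compound 2 to compound 4 (0.71 log units; beyond the scatter)), so the protected chain and the fully hydroxylated ring lie well apart.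

Going by these compounds, whether an amine, a carboxylic acid or a longer chain on this aromatic nitrogen would shift the number remains open. Nothing at hand explains why these steps differ in size.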